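The source may report more compounds than this note shows. Statements on the series, on what has been measured and on what is new or still open speak of the compounds shown alone.

Measured in an ADME assay on RAW264.7 cells (Mus musculus) for cytotoxicity, read by neutral red uptake, with a stated time of 24 h; on this read-out lower numbers stand for higher toxicity in this test and higher numbers for lower toxicity in this test:
compound 1 `O=C(CN1C(=O)CSC1=O)NOCc1ccccc1` gives > 128000 nM, which is a limit of the assay.
compound 2 `C=CCONC(=O)CN1C(=O)CSC1=O` gives > 128000 nM, again a limit of the assay.
compound 3 `CC(C(=O)NOCc1ccccc1)N1C(=O)S/C(=C\c2ccc(C(F)(F)F)cc2)C1=O` gives > 128000 nM, also a limit of the assay.

The change from compound 1 to compound 2 is vinyl in place of phenyl on a saturated chain carbon bound to an oxygen. The step it made in this assay, a step that the two limits leave unreadable from compound 1 to compound 2, cannot be sized because both values sit at the limit of > 128000 nM in this assay, at which 3 of the 3 values shown sit.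

Compound 4 `C=CCONC(=O)C(C)N1C(=O)S/C(=C\c2ccc(C(F)(F)F)cc2)C1=O` is not yet measured. It differs from compound 3 by vinyl in place of phenyl on a saturated chain carbon bound to an oxygen, the same change as that from compound 1 to compound 2, at the same place. The difference between the core of compound 1 and the core of compound 3 is not broken down here.

For compound 4 in this assay the expected step is a step that the limit leaves unreadable from compound 3 to compound 4. This expectation rests on compound 3 sitting at the limit > 128000 nM and on the unreadable step that the two limits leave unreadable from compound 1 to compound 2. Compound 4 is therefore expected at 200000 nM, most likely again reported only as a limit, between 100000 nM and 600000 nM.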

Compound 4, half-maximal cytotoxic concentration: > 128000 nM
Compound 4: only a limit was reported (the forecaster's own chance of this, stated with the estimate: 85%); the middle value lies beyond the limit too.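

Compound 3 and compound 4 both give only a limit of the assay in this assay, so no step can be read between them: the limit of > 128000 nM in this assay, at which 4 of the 4 values shown sit.

The compounds shown leave open whether vinyl in place of phenyl alters the half-maximal cytotoxic concentration on either core.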